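The source may hold more compounds than are shown below. What is called first, only, known or untested is meant among the compounds shown, and "the series" means these compounds.

Measured compounds in a functional assay on DU-145 cells (Homo sapiens) for cytotoxicity, read by CCK-8 assay, with a stated time of 4 days; a lower number here means a stronger inhibitor, a higher number a weaker inhibitor:
compound 1, `Oc1ccc(-c2cc(-c3ccccc3O)cc(-c3cccc(O)c3)n2)cc1`, 5370 nM
compound 2, `Oc1ccc(-c2cc(-c3cccc(O)c3)cc(-c3cccc(O)c3)n2)cc1`, 1940 nM
compound 3, `Oc1ccc(-c2cc(-c3ccccc3O)cc(-c3ccc(O)cc3)n2)cc1`, 980 nM

Compound 1 gives the highest number of the three in this assay, so it is the weakest of the measured set; its nearest neighbour is compound 2, the step being a 2.8-fold lower number from compound 1 to compound 2 (0.44 log units; beyond the scatter), and the furthest is compound 3, with a 5.5-fold lower number from compound 1 to compound 3 (0.74 log units; beyond the scatter).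

Compound 4, `Oc1cccc(-c2cc(-c3ccccc3O)cc(-c3ccccc3O)n2)c1`, has not been measured. It differs from compound 1 in one place: 2-hydroxyphenyl in place of 4-hydroxyphenyl on an aromatic carbon.

Among the measured compounds shown here, two measured steps bear on this. Exchanging a 2-hydroxyphenyl for a 3-hydroxyphenyl gave a 2.8-fold lower number from compound 1 to compound 2 (0.44 log units; beyond the scatter), and exchanging a 3-hydroxyphenyl for a 4-hydroxyphenyl gave a 5.5-fold lower number from compound 1 to compound 3 (0.74 log units; beyond the scatter). For the measured compounds named here, both steps move away from the 2-hydroxyphenyl pattern and both lower the number, so within this set the 2-hydroxyphenyl appears to be the least favourable of the three arrangements and the 4-hydroxyphenyl the most favourable; no measured compound contradicts this, though the set is small. The change from compound 1 to compound 4 runs in the opposite direction, putting a second 2-hydroxyphenyl in place of the 4-hydroxyphenyl, so a higher number is expected, of a size in the range of the two measured steps.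

For compound 4 the expected result in this assay is 16000 nM, with a range of 6000 nM to 45000 nM, corresponding to an expected step of a 3.0-fold higher number from compound 1 to compound 4 (0.47 log units; beyond the scatter).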

Compound 4, half-maximal inhibitory concentration: 3980 nM
Beside the measured number, compound 4's estimate is 4.0-fold (0.60 log units) above it; the whole stated range lies above it.
By their numbers in this assay, from the lowest: compounds 3 and 2 (each within the scatter of the next); then compounds 4 and 1 (each within the scatter of the next).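

In this assay, 2-hydroxyphenyl in place of 4-hydroxyphenyl on the carbon next to the ring nitrogen gives a 1.3-fold lower number from compound 1 to compound 4 (0.13 log units; within the scatter), so at this place the two groups are not told apart and the hydroxyl can occupy either arrangement on this ring with no readable change. The earlier exchanges, made at other places on the shared core, gave a 2.8-fold lower number from compound 1 to compound 2 (0.44 log units; beyond the scatter) and a 5.5-fold lower number from compound 1 to compound 3 (0.74 log units; beyond the scatter), both beyond the scatter, so the rule drawn from them, that a 2-hydroxyphenyl is the poorer group, does not carry over to this place and the hydroxyphenyl preference depends on where on the core the exchange is made. No supporting data are available to account for this flat step at this place.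

Open, from the compounds shown here alone, is whether this place tolerates anything other than a hydroxyphenyl at all, for instance an unsubstituted phenyl, a methoxyphenyl or an aminophenyl, which would show whether the hydroxyl here matters to the number. Also open, going by these compounds, is whether the same flat step would appear with a 3-hydroxyphenyl at this place on the core of compound 1.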